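Swapping the carbamate end of an inactive stilbene-like amide

The source may hold more compounds than are shown below. What is called first, only, known or untested is meant among the compounds shown, and "the series" means these compounds.

Compound 1 (`COc1ccc(/C(=C(/CCNC(=O)Oc2ccccc2)c2ccccc2)c2ccccc2)cc1`) was tested in a functional assay on MCF7 cells (Homo sapiens) for cytotoxicity, read by MTT assay, with a stated time of 72 h (a higher number here means a weaker inhibitor, a lower number a stronger inhibitor), where compound 1 gives "not active" (no number reported). Two close relatives share its core. Compound 2 (`CCN(CC)C(=O)NCC/C(=C(\c1ccccc1)c1ccc(OC)cc1)c1ccccc1`) carries a diethylamino urea on the side chain; in this assay compound 2 gives > 50000 nM, which is a limit of the assay rather than a number. Compound 3 (`COc1ccc(/C(=C(/CCNC(=O)C(=O)NCc2ccccc2)c2ccccc2)c2ccccc2)cc1`) carries an oxalamide ending in a benzyl group; in this assay compound 3 gives > 50000 nM, again a limit. Among the measured compounds shown here, the only single-point comparison available, a step that the two limits leave unreadable from compound 2 to compound 3, therefore cannot be read for size: both ends sit at the limit of > 50000 nM in this assay, at which 2 of the 3 values shown sit.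

Compound 4 (`COc1ccc(/C(=C(/CCNC(=O)C(=O)N2CCCCC2)c2ccccc2)c2ccccc2)cc1`) is now considered. Relative to compound 1 the change is (piperidin-1-yl)carbonyl in place of phenoxy on a carbonyl carbon. For the measured compounds named here, no measured step resembles this change directly, and the two steps that are available tell nothing of size. What the three values do share is an absence of measurable inhibition, so the expectation for compound 4 is no step beyond the scatter and most probably another limit. Compound 4 is estimated at 70000 nM, with a plausible range from 20000 nM to 250000 nM.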

Compound 4, half-maximal inhibitory concentration: > 50000 nM
Compound 4 was reported as a limit; the forecaster's own chance of this, stated with the estimate: 80%; the middle value does not contradict the limit.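

Compound 4 sits at the same limit as compound 2 and compound 3, so the steps from either of them to compound 4 cannot be read for size: the limit of > 50000 nM in this assay, at which 3 of the 4 values shown sit.

The compounds shown leave open whether any other end group on the side chain of the shared core would give a real number in this assay.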